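Chloropyridazine in Place of the Cyclic Amidine

This account rests on a few compounds, and the source may have more. Where it says the series, first, only, none or still open, it means among the compounds named here.

Among the compounds with values here, compound 3 `c1ccc2c(c1)CCC(CNCCCNC1=NCCN1)O2` gives 6.31 nM in an assay on isolated protein (Bos taurus) with 5-hydroxytryptamine receptor 1D (Homo sapiens) as the target (on this read-out higher numbers stand for weaker inhibition and lower numbers for stronger inhibition), the only plain number among the three values shown. Compound 1 `COc1ccc2c(c1)CCC(CNCCCNC1=NCCCN1)O2` sits at a limit of this assay with > 1000 nM. Compound 2 `c1ccc2c(c1)CCCC(CNCCCNC1=NCCCN1)O2` likewise sits at a limit of this assay with > 1000 nM. Within the data shown here, no step between measured compounds is available, and the limit of > 1000 nM in this assay, at which 2 of the 3 values shown sit, marks where two of the three values rest. Compound 4 `Clc1ccc(NCCCNCC2CCc3ccccc3O2)nn1` differs from compound 3 by a group of 7 heavy atoms (4 carbon, 2 nitrogen, 1 chlorine; one six-membered aromatic ring with 2 hetero atoms) in place of a group of 5 heavy atoms (3 carbon, 2 nitrogen; one five-membered non-aromatic ring with 2 hetero atoms), on an amine nitrogen. Among the measured compounds shown here, with no measured step to lean on, the expected step of a 32-fold higher number from compound 3 to compound 4 (1.50 log units; beyond the scatter) is one toward weaker inhibition, beyond the usual scatter. Compound 4 is therefore estimated at 200 nM, with a range from 30 nM to 3000 nM.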

Compound 4, half-maximal inhibitory concentration: 2 nM
Compound 4: the middle estimate sits 100-fold (2.00 log units) above what was measured, and the stated range ends above it.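

The ring on the amine nitrogen need not be the five-membered non-aromatic one: in this assay the exchange for 6-chloropyridazin-3-yl gives a 3.2-fold lower number from compound 3 to compound 4 (0.50 log units; beyond the scatter) and so modestly strengthens inhibition. Within the data shown here, this is the first measured step at this position. Nothing shown here accounts for the gain.

The compounds shown leave open whether the chlorine matters, since no pyridazine carrying a hydrogen, a fluorine or a methoxy group in its place appears. They also leave open whether 6-chloropyridazin-3-yl would hold on the core of compound 1 or compound 2.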